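A few compounds are considered here, and "the series" means these few. Any claim that something is new, unique, unknown or untested is made for them only; others in the source may bear on it.

Measured so far in an ADME assay on the whole organism for cytotoxicity, with Artemia salina as the target, with a stated time of 24 h; on this read-out lower numbers stand for an effect already at smaller amounts and higher numbers for an effect only at larger amounts of compound:
compound 1, `Cc1ccc(S(=O)(=O)NC(=O)Nc2ccccc2C(=O)/C=C/c2ccccc2)cc1`, gives 25 ug/mL
compound 2, `Cc1ccc(/C=C/C(=O)c2ccccc2NC(=O)NS(=O)(=O)c2ccc(C)cc2)cc1`, gives 15.3 ug/mL
compound 3, `Cc1ccc(S(=O)(=O)NC(=O)Nc2ccccc2C(=O)/C=C/c2ccc(N(C)C)cc2)cc1`, gives 38.1 ug/mL

Compound 3 holds the highest of the three numbers in this assay; its gap to compound 1 is within the scatter, while its gap to compound 2 is beyond it, as a 2.5-fold higher number from compound 2 to compound 3 (0.40 log units; beyond the scatter) shows. The next member of the series is compound 4, `Cc1ccc(S(=O)(=O)NC(=O)Nc2ccccc2C(=O)/C=C/c2ccc(O)cc2)cc1`. It differs from compound 3 in one place: hydroxy in place of dimethylamino on an aromatic carbon.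

Among the compounds with values here, no measured step puts a hydroxy onto this aromatic carbon. The step has to be judged from the two measured steps that change the group on the same carbon, a 1.5-fold higher number from compound 1 to compound 3 (0.18 log units; within the scatter) and a 2.5-fold higher number from compound 2 to compound 3 (0.40 log units; beyond the scatter). Neither moved the number by more than a modest amount, and the third step in the set, a 1.6-fold lower number from compound 1 to compound 2 (0.21 log units; within the scatter), stayed within the scatter. A change at this carbon is therefore expected to shift this assay by a modest amount at most. Compound 1 gives 25 ug/mL and compound 2 gives 15.3 ug/mL; compound 4 is expected to land in that neighbourhood, somewhat under compound 3. Compound 4 is expected to give about 28 ug/mL, with a range from 14 ug/mL to 55 ug/mL. The estimate amounts to an expected step of a 1.4-fold lower number from compound 3 to compound 4 (0.13 log units; within the scatter).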

Compound 4, concentration for half-maximal effect: 24.3 ug/mL
For compound 4 the middle estimate is 1.2-fold (0.06 log units) above the measured one, and the stated range covers the measured number.
By their numbers in this assay, from the lowest: compounds 2, 4, 1 and 3 (each within the scatter of the next, the first and the last beyond it).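

Hydroxy now joins hydrogen, methyl and dimethylamino on this aromatic carbon, para to a large group, and in this assay all three new steps stay within the scatter (a 1.6-fold lower number from compound 3 to compound 4 (0.20 log units; within the scatter); a 1.6-fold higher number from compound 2 to compound 4 (0.20 log units; within the scatter); a 1.0-fold lower number from compound 1 to compound 4 (0.01 log units; within the scatter)). Exchanging dimethylamino, with no hydrogen-bond donor, for hydroxy, with one, and with fewer heavy atoms, therefore gives no step beyond the scatter, and compound 4 sits within the scatter of each of the other three compounds. Among the four compounds, the only step beyond the scatter remains the modest one between methyl and dimethylamino (a 2.5-fold higher number from compound 2 to compound 3 (0.40 log units; beyond the scatter)), and no measurement at hand accounts for the size of any of these steps.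

The compounds shown leave open whether this narrow spread would hold for a carboxylic acid, a primary amine or a chlorine on the same carbon. They also leave open whether a change at another place on the shared core would move the number in this assay any further than these groups do.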